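A few compounds are considered here, and "the series" means these few. Any claim that something is new, unique, unknown or untested is made for them only; others in the source may bear on it.

Measured so far in a functional assay on MDA-MB-231 cells (Homo sapiens) for cytotoxicity, read by MTT assay, with a stated time of 48 h; on this read-out lower numbers stand for stronger inhibition and higher numbers for weaker inhibition:
- compound 1 `O=C(O)CN1C(=O)/C(=C/c2nc3ccccc3n2Cc2ccc(Br)cc2F)SC1=S` gives 28400 nM
- compound 2 `N#Cc1ccc(Cn2c(/C=C3\SC(=S)N(CC(=O)O)C3=O)nc3ccccc32)cc1` gives 11200 nM
- compound 3 `Cc1ccc(Cn2c(/C=C3\SC(=S)N(CC(=O)O)C3=O)nc3ccccc32)cc1` gives 1040 nM

Compound 2 stands second highest of the three numbers: it lies below compound 1 by a 2.5-fold lower number from compound 1 to compound 2 (0.40 log units; beyond the scatter) and above compound 3 by an 11-fold lower number from compound 2 to compound 3 (1.03 log units; beyond the scatter). Compound 4 `COc1cc(Cn2c(/C=C3\SC(=S)N(CC(=O)O)C3=O)nc3ccccc32)cc(OC)c1` differs from compound 2 by 3,5-dimethoxyphenyl in place of 4-cyanophenyl on a saturated chain carbon bound to an aromatic nitrogen. Among the compounds with values here, the steps that bear on it are the swaps of the group on the saturated chain carbon: a 2.5-fold lower number from compound 1 to compound 2 (0.40 log units; beyond the scatter) (modest) and a 27-fold lower number from compound 1 to compound 3 (1.44 log units; beyond the scatter) (large), with an 11-fold lower number from compound 2 to compound 3 (1.03 log units; beyond the scatter) showing that a change on the aromatic carbon alone can move the number far. Within the data shown here, no measured compound carries a 3,5-dimethoxyphenyl, so the direction is uncertain; a lower number of intermediate size is expected, a 3.2-fold lower number from compound 2 to compound 4 (0.51 log units; beyond the scatter). Compound 4 is estimated at 3500 nM, range 900 nM to 14000 nM.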

Compound 4, half-maximal inhibitory concentration: 1280 nM
Beside the measured number, compound 4's estimate is 2.7-fold (0.44 log units) above it, within the range that was stated.
By their numbers in this assay, from the lowest: compounds 3 and 4 (each within the scatter of the next); then compound 2; then compound 1.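

In this assay, 3,5-dimethoxyphenyl on the saturated chain carbon bound to an aromatic nitrogen improves on both 4-cyanophenyl (an 8.8-fold lower number from compound 2 to compound 4 (0.94 log units; beyond the scatter)) and 4-bromo-2-fluorophenyl (a 22-fold lower number from compound 1 to compound 4 (1.35 log units; beyond the scatter)), so a low number at this position is not confined to 4-methylphenyl. Against 4-methylphenyl, the change gives no separation (a 1.2-fold higher number from compound 3 to compound 4 (0.09 log units; within the scatter)). Nothing available explains these steps. On these data alone, what an amine or a hydroxyl in place of the methoxy groups of compound 4 would give stays open. So does the effect of a longer chain in place of the saturated chain carbon.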